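The source may report more compounds than this note shows. Statements on the series, on what has been measured and on what is new or still open speak of the compounds shown alone.

Compound 2 `O=[N+]([O-])c1cc2c(OCCC3CCCCN3)c(-c3cc(Cl)cc(Cl)c3)c(O)nc2cc1Cl` gives 24 nM in a functional assay on cells (Pituitary gland cell) for antagonist activity at Gonadotropin-releasing hormone receptor (Rattus norvegicus) (on this read-out higher numbers stand for weaker inhibition and lower numbers for stronger inhibition), and compound 1 `O=[N+]([O-])c1cc2c(OCCC3CCCCN3)c(-c3cccc(Cl)c3)c(O)nc2cc1Cl` gives 40 nM; the step of a 1.7-fold lower number from compound 1 to compound 2 (0.22 log units; within the scatter) falls within the scatter, so the two cannot be separated. Compound 3 `O=[N+]([O-])c1cccc(-c2c(O)nc3cc(Cl)c([N+](=O)[O-])cc3c2OCCC2CCCCN2)c1` differs from compound 2 by 3-nitrophenyl in place of 3,5-dichlorophenyl on an aromatic carbon. Among the measured compounds shown here, the one measured step touches the same phenyl ring yet stayed within the scatter, and no measured compound carries a nitro group there, so little guidance exists. Compound 3 is therefore expected to land near compound 2, with a step of a 2.1-fold higher number from compound 2 to compound 3 (0.32 log units; beyond the scatter), and an estimated value of 50 nM, ranging from 15 nM to 170 nM.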

Compound 3, half-maximal inhibitory concentration: 100 nM
Beside the measured number, compound 3's estimate is 2.0-fold (0.30 log units) below it; measured number inside the range.
By their numbers in this assay, from the lowest: compounds 2 and 1 (each within the scatter of the next); then compound 3.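

In this assay, the phenyl ring of the core now proves sensitive to what it carries: putting nitro in place of chloro alone gives a 2.5-fold higher number from compound 1 to compound 3 (0.40 log units; beyond the scatter) and so moves the number beyond the scatter, which the earlier added chloro did not do. The full swap of 3,5-dichlorophenyl for 3-nitrophenyl gives a 4.2-fold higher number from compound 2 to compound 3 (0.62 log units; beyond the scatter) on the same side. Nothing measured here bears on the cause of this change. On these data alone, whether the loss belongs to nitro in particular stays open. A methoxy group or an amine in the same place would help to show that.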